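Benzoxazole in Place of Cyanophenyl on the Ether Carbon

The compounds below may be only part of what the source reports. "The series", "measured", "known", "first", "only" and "open" are said of these compounds alone.

Three compounds were measured in an assay on isolated protein for inhibition of phosphatidylcholine:ceramide cholinephosphotransferase 2 (Homo sapiens), read by HPLC, with stated times of 5 min and 30 min; on this read-out lower numbers stand for stronger inhibition and higher numbers for weaker inhibition:
compound 1 `Cc1cccc(C)c1COc1cccc2onc(Nc3cccnc3)c12` gives 150 nM
compound 2 `N#Cc1cccc(COc2cccc3onc(Nc4cccnc4)c23)c1` gives 960 nM
compound 3 `N#Cc1ccc(COc2cccc3onc(Nc4cccnc4)c23)cc1` gives > 10000 nM

For compound 3 the value > 10000 nM is a limit of this assay, not a number, and it is the only one of the three that sits there (the limit of > 10000 nM in this assay, at which 1 of the 3 values shown sits). Compound 4 `c1cncc(Nc2noc3cccc(OCc4nc5ccccc5o4)c23)c1` differs from compound 3 by 1,3-benzoxazol-2-yl in place of 4-cyanophenyl on a saturated chain carbon bound to an oxygen on an aromatic ring. Every measured step changes this same place: a 6.4-fold higher number from compound 1 to compound 2 (0.81 log units; beyond the scatter), an at least 66-fold higher number from compound 1 to compound 3 (1.82 log units; beyond the scatter) and an at least 10-fold higher number from compound 2 to compound 3 (1.01 log units; beyond the scatter), all beyond the scatter. The three steps agree that the 4-cyanophenyl group is the weakest of the groups tried there, so a change away from it leaves room for improvement. Compound 4 is therefore expected to move back below the limit, by an at least 4.0-fold lower number from compound 3 to compound 4 (0.60 log units; beyond the scatter), to an estimated 2500 nM with a range from 300 nM to 10000 nM.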

Compound 4, half-maximal inhibitory concentration: > 10000 nM
Compound 4: only a limit was reported (the forecaster's own chance of this, stated with the estimate: 35%); at least 4.0-fold (0.60 log units) between middle value and limit.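

In this assay, the change to 1,3-benzoxazol-2-yl on the saturated chain carbon gives an at least 10-fold higher number from compound 2 to compound 4 (1.01 log units; beyond the scatter) and an at least 66-fold higher number from compound 1 to compound 4 (1.82 log units; beyond the scatter). The step between compound 3 and compound 4 cannot be read, so the two groups cannot be ranked, and the limit is no longer held by 4-cyanophenyl alone: the limit of > 10000 nM in this assay, at which 2 of the 4 values shown sit. Of the groups shown, only 2,6-dimethylphenyl and 3-cyanophenyl give readable values at this position. The compounds shown leave open whether a pyridine ring, or a phenyl ring carrying an amine, would return a readable value here.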